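A few compounds are considered here, and "the series" means these few. Any claim that something is new, unique, unknown or untested is made for them only; others in the source may bear on it.

Measured so far:
Compound 1 `C=C(F)C(=O)Nc1cc(Nc2nccc(-c3cn(C)c4ccccc34)n2)c(OC)cc1N(C)CCN(C)C` gives 2460 nM in a functional assay on A549 cells (Homo sapiens) for antiproliferative activity, read by MTT assay, with a stated time of 72 h; on this read-out higher numbers stand for weaker inhibition and lower numbers for stronger inhibition.
Compound 2 `C=C(Cl)C(=O)Nc1cc(Nc2nccc(-c3cn(C)c4ccccc34)n2)c(OC)cc1N(C)CCN(C)C` gives 7520 nM in this assay.
Compound 3 `COc1cc(N(C)CCN(C)C)c(NC(=O)C=C(C)C)cc1Nc1nccc(-c2cn(C)c3ccccc23)n1` gives 4100 nM in this assay.

All three share one core and differ only in the group on the carbonyl carbon of the amide. Compound 3 holds the second highest number of the three, but its gaps to both neighbours are within the scatter: a 1.7-fold higher number from compound 1 to compound 3 (0.22 log units; within the scatter) and a 1.8-fold lower number from compound 2 to compound 3 (0.26 log units; within the scatter). Among the measured compounds shown here, the only step that clearly moved the number is a 3.1-fold higher number from compound 1 to compound 2 (0.49 log units; beyond the scatter).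

Compound 4 `CCC/C=C\C(=O)Nc1cc(Nc2nccc(-c3cn(C)c4ccccc34)n2)c(OC)cc1N(C)CCN(C)C` is not yet measured. It differs from compound 3 in one place: pent-1-en-1-yl in place of 2-methylprop-1-en-1-yl on a carbonyl carbon. The two steps that bear on this change, from compound 1 and from compound 2 to compound 3, each swapped the group on the same carbonyl carbon and each stayed within the scatter. For the measured compounds named here, no measured pair swaps one alkyl pattern on that double bond for another, so the data give no direction. The expectation is therefore a step of no more than the scatter, a 1.1-fold higher number from compound 3 to compound 4 (0.04 log units; within the scatter), with compound 4 estimated at 4500 nM in this assay, within 1500 nM to 13000 nM.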

Compound 4, half-maximal inhibitory concentration: 808 nM
Estimate against measurement, compound 4: 5.6-fold (0.75 log units) above, outside the stated range (below it).
By their numbers in this assay, from the lowest: compound 4; then compounds 1, 3 and 2 (each within the scatter of the next, the first and the last beyond it).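

In this assay, the group on the carbonyl carbon proves able to move the number far more than the first three compounds suggested: pent-1-en-1-yl in place of 2-methylprop-1-en-1-yl gives a 5.1-fold lower number from compound 3 to compound 4 (0.71 log units; beyond the scatter), although both groups are open chains with one double bond, no hydrogen-bond donors or acceptors, and a count of only 5 carbon against 4 carbon. The halogen-bearing groups compare the same way, with a 3.0-fold lower number from compound 1 to compound 4 (0.48 log units; beyond the scatter) and a 9.3-fold lower number from compound 2 to compound 4 (0.97 log units; beyond the scatter), so compound 4 has the lowest number of the four, and its step to each of the others lies beyond the scatter. Nothing shown here explains how this change in the chain lowers the number.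

The compounds shown cannot separate the effect of chain length from that of the unbranched shape, since no shorter straight chain such as prop-1-en-1-yl and no longer one such as hept-1-en-1-yl stands among them. They also leave open whether the double bond is needed, which a saturated pentyl group on the same carbonyl carbon would test, and whether a chain ending in an amine would keep the lower number.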